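The source may hold more compounds than are shown below. What is called first, only, known or untested is meant among the compounds shown, and "the series" means these compounds.

Working notes on the series. In an ADME assay on Huh-7 cells (Homo sapiens) for cytotoxicity, read by MTT assay, with a stated time of 96 h (on this read-out higher numbers stand for lower toxicity in this test and lower numbers for higher toxicity in this test), compound 1 `COc1cc(NCc2ccc(C)o2)ccc1-c1cnco1` gives 63400 nM as its half-maximal cytotoxic concentration, compound 2 `COc1ccc(-c2cnco2)cc1NCc1ccc(C)s1` gives 52900 nM and compound 3 `COc1cc(NCc2ccc(C)s2)ccc1-c1cnco1` gives 34400 nM on the same read-out. Compound 3 stands within the scatter of both other compounds, so these three numbers set up no order.

The next compound is compound 4 `COc1cc(NCc2ccc(Cl)s2)ccc1-c1cnco1`. It carries chloro in place of methyl on an aromatic carbon and so turns 5-methylthiophen-2-yl to 5-chlorothiophen-2-yl.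

Going by the values given here, only one measured step bears on this, and only indirectly: a 1.8-fold lower number from compound 1 to compound 3 (0.27 log units; within the scatter) for 5-methylthiophen-2-yl in place of 5-methylfuran-2-yl. No measured pair replaces the methyl itself, so the size of this change is not shown directly. Among the compounds with values here, the one step at hand stays within the scatter, so no step beyond the scatter is expected in this assay and only a weak lean in direction is assumed. The estimated step is a 1.1-fold lower number from compound 3 to compound 4 (0.06 log units; within the scatter) and it is expected to be small. For compound 4 the estimated value is 30000 nM (expected range 13000 nM to 65000 nM).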

Compound 4, half-maximal cytotoxic concentration: 43200 nM
Estimate against measurement, compound 4: 1.4-fold (0.16 log units) below; low and high end bracket the measured number.
By their numbers in this assay, from the lowest: compounds 3, 4, 2 and 1 (each within the scatter of the next).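

Going by these compounds alone, this is the first direct read on the methyl itself: in this assay chloro in place of methyl on an aromatic carbon, next to the ring sulfur, gives a 1.3-fold higher number from compound 3 to compound 4 (0.10 log units; within the scatter) and so does not separate the two compounds at this position. Exchanging the ring and its substituent in one step, with 5-chlorothiophen-2-yl in place of 5-methylfuran-2-yl, gives a 1.5-fold lower number from compound 1 to compound 4 (0.17 log units; within the scatter) and likewise stays within the scatter, so none of the three exchanges now read at this group sets compounds 1, 3 and 4 apart on this read-out. Nothing at hand offers an explanation for these numbers.

Going by these compounds, whether an amine or a carboxylic acid in place of the chloro on this thiophene carbon would carry the number beyond the scatter stays open. Also open, on these data alone, is whether chloro in place of methyl gives a comparable step on the core of compound 2, where the same kind of side chain is attached differently.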